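Replacing the Nitrophenyl Group of Compound 2

The source may hold more compounds than are shown below. What is called first, only, known or untested is meant among the compounds shown, and "the series" means these compounds.

In an ADME assay on HeLa cells (Homo sapiens) for inhibition, read by cell counting (a lower number here means a stronger inhibitor, a higher number a weaker inhibitor), compound 1 `CSc1nc(-c2ccccc2)c(C#N)c(N2CCN(c3ccnc4cc(Cl)ccc34)CC2)n1` gives > 250000 nM, which is a limit of the assay rather than a number. Within the data shown here, compound 2 `CSc1nc(NCCCCNc2ccnc3cc(Cl)ccc23)c(C#N)c(-c2ccc([N+](=O)[O-])cc2)n1` gives 890 nM in this assay, the only full number in this set. Compound 3 `COc1ccc(-c2nc(SC)nc(NCCCCNc3ccnc4cc(Cl)ccc34)c2C#N)cc1OC` differs from compound 2 by 3,4-dimethoxyphenyl in place of 4-nitrophenyl on an aromatic carbon. Among the measured compounds shown here, no measured step bears on this kind of change, so compound 3 is expected to show a 1.7-fold higher number from compound 2 to compound 3 (0.23 log units; within the scatter), a shift toward weaker inhibition that need not rise beyond the scatter. Compound 3 is therefore estimated at 1500 nM, with a range from 400 nM to 6000 nM.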

Compound 3, half-maximal inhibitory concentration: 20000 nM
Estimate against measurement, compound 3: 13-fold (1.12 log units) below; the measured number lies above the stated range.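

The position on the aromatic carbon ortho to a cyano group turns out to be sensitive to the aryl group it carries: in this assay, 3,4-dimethoxyphenyl in place of 4-nitrophenyl gives a 22-fold higher number from compound 2 to compound 3 (1.35 log units; beyond the scatter). Among these compounds, this is the first single change in the set, and it lies well beyond the scatter, so the aryl group here is not interchangeable. Nothing shown gives a cause for this step. As far as these compounds go, it remains open which part of the change carries the step, the departing nitro group or the entering methoxy groups. A single 4-methoxyphenyl group at this position would separate the two.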